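Biaryl in place of benzyl ether on the sulfonyl aryl amide

A few compounds are considered here, and "the series" means these few. Any claim that something is new, unique, unknown or untested is made for them only; others in the source may bear on it.

Within the set, compound 3 `CS(=O)(=O)c1ccc(OCc2ccccc2)c(C(=O)N2Cc3cc(C(F)(F)F)cnc3C2)c1` sits at the high end of an assay on CHO cells for inhibition of sodium- and chloride-dependent glycine transporter 1 (Homo sapiens), read by scintillation counting (on this read-out lower numbers stand for an effect already at smaller amounts and higher numbers for an effect only at larger amounts of compound), giving 805 nM. Compound 1 `CC(C)Oc1ccc(S(C)(=O)=O)cc1C(=O)N1Cc2cc(C(F)(F)F)cnc2C1` gives 70 nM and compound 2 `CC(C)COc1ccc(S(C)(=O)=O)cc1C(=O)N1Cc2cc(C(F)(F)F)cnc2C1` gives 30 nM; the steps of a 12-fold higher number from compound 1 to compound 3 (1.06 log units; beyond the scatter) and a 27-fold higher number from compound 2 to compound 3 (1.43 log units; beyond the scatter) are both large, while a 2.3-fold lower number from compound 1 to compound 2 (0.37 log units; beyond the scatter) is modest. Compound 4 `CS(=O)(=O)c1ccc(-c2ccc(F)c(F)c2)c(C(=O)N2Cc3cc(C(F)(F)F)cnc3C2)c1` carries 3,4-difluorophenyl in place of benzyloxy on an aromatic carbon. Among the measured compounds shown here, no measured step removes the ether oxygen or attaches an aryl ring directly to the core, so none bears squarely on this change; the measured steps only show that a benzyl on the oxygen goes with a higher number than the alkyl groups. With the benzyloxy gone, a lower number than compound 3 is expected, but the size is a guess rather than a derivation. Compound 4 is estimated at 200 nM, between 40 nM and 1000 nM, an expected step of a 4.0-fold lower number from compound 3 to compound 4 (0.60 log units; beyond the scatter).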

Compound 4, half-maximal effective concentration in the sodium- and chloride-dependent glycine transporter 1 assay: 30 nM
The estimate for compound 4 lay 6.7-fold (0.82 log units) above the measured number; measured number outside the range, below it.
By their numbers in the sodium- and chloride-dependent glycine transporter 1 assay, from the lowest: compounds 2 and 4 (each within the scatter of the next); then compound 1; then compound 3.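

At this aromatic carbon, para to a methylsulfonyl group, an aryl ring need not be costly when attached directly: in the sodium- and chloride-dependent glycine transporter 1 assay replacing benzyloxy with 3,4-difluorophenyl gives a large step (a 27-fold lower number from compound 3 to compound 4 (1.43 log units; beyond the scatter)), with compound 3 at 805 nM and compound 4 at 30 nM. In the sodium- and chloride-dependent glycine transporter 1 assay the same group also holds up against the small alkoxy groups (no change at the digits printed from compound 2 to compound 4 (within the scatter); a 2.3-fold lower number from compound 1 to compound 4 (0.37 log units; beyond the scatter)), so among these compounds an ether oxygen at this position is not required. In a physicochemical assay for solubility (a lower number here means a less soluble compound, a higher number a more soluble compound), compound 3 gives 72 ug/mL and compound 4 gives 42 ug/mL, a difference within the scatter (a 1.7-fold lower number from compound 3 to compound 4 (0.23 log units; within the scatter)). No supporting data bear on why these steps arise.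

Open, going by these compounds, is whether the two fluorines contribute at all. An unsubstituted phenyl, a pyridine ring or a benzylamine at this carbon would test how far the result extends.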